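Sulfonamide ester series: removing one ring fluorine

A few compounds are considered here, and "the series" means these few. Any claim that something is new, unique, unknown or untested is made for them only; others in the source may bear on it.

Among the compounds with values here, compound 1 `CCOC(=O)c1cnc2ccc(-c3cnc(OC)c(NS(=O)(=O)c4ccc(F)cc4F)c3)cn12` gives 90 nM in a functional assay on HCT-116 cells (Homo sapiens) for antiproliferative activity, read by sulforhodamine B assay, with a stated time of 72 h (on this read-out lower numbers stand for stronger inhibition and higher numbers for weaker inhibition), and stands lowest of the two numbers measured so far. Compound 2 `COc1ncc(-c2ccc3ncc(C(=O)O)n3c2)cc1NS(=O)(=O)c1ccc(F)cc1F` gives 1310 nM in this assay; the step of a 15-fold higher number from compound 1 to compound 2 (1.16 log units; beyond the scatter) is hydrogen in place of ethyl on an oxygen next to a carbonyl group. Compound 3 `CCOC(=O)c1cnc2ccc(-c3cnc(OC)c(NS(=O)(=O)c4ccc(F)cc4)c3)cn12` differs from compound 1 by hydrogen in place of fluoro on an aromatic carbon, ortho to a large group and meta to a fluoro group, so that 2,4-difluorophenyl becomes 4-fluorophenyl. Within the data shown here, no measured step touches this ring; the one step known lies at the oxygen next to the carbonyl group and gives no guide here. Compound 3 is therefore expected to stay close to compound 1, with a step of a 1.3-fold higher number from compound 1 to compound 3 (0.12 log units; within the scatter) that is not expected to go beyond the scatter. The estimate for compound 3 in this assay is 120 nM, within 40 nM to 400 nM.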

Compound 3, half-maximal inhibitory concentration: 640 nM
Compound 3: the middle estimate sits 5.3-fold (0.73 log units) below what was measured; the measured number lies above the stated range.
By their numbers in this assay, from the lowest: compound 1; then compound 3; then compound 2.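

In this assay, the 2,4-difluorophenyl group is a sensitive part of the ester series: the change to 4-fluorophenyl gives a 7.1-fold higher number from compound 1 to compound 3 (0.85 log units; beyond the scatter). Within the data shown here, the only earlier step, a 15-fold higher number from compound 1 to compound 2 (1.16 log units; beyond the scatter), lay at the ester, so the number now moves at a second, separate place in the molecule, and with the loss of a single heavy atom. Nothing at hand accounts for this step.

On these data alone, whether fluoro is specifically required on the aromatic carbon ortho to a large group stays open, and chloro, methyl or methoxy at that place would test this. Also open, as far as these compounds go, is whether removing this fluoro has a similar effect when the ester is replaced by the carboxylic acid of compound 2, or by an amide.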